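A few compounds are considered here, and "the series" means these few. Any claim that something is new, unique, unknown or untested is made for them only; others in the source may bear on it.

Of the compounds shown here, three sharing a core have been measured in an ADME assay on microsomes from liver (Homo sapiens) for metabolic stability; on this read-out higher numbers stand for a longer-lived compound and lower numbers for a shorter-lived compound. In that assay, compound 1 (`CCC(CC)c1nn(CCO)c2c1N=C(c1ccccc1)CNC2=O`) gives 0.333 h, compound 2 (`CCC(CC)c1nn(CCCO)c2c1N=C(c1ccc(-n3ccnc3C)cc1)CNC2=O`) gives 0.1 h and compound 3 (`CCC(CC)c1nn(CCCO)c2c1N=C(c1ccc(OC)c(OC)c1)CNC2=O`) gives 0.733 h. Compound 3 has the highest number of the three, beyond the scatter against both others, with compound 1 the nearest. Compound 4 (`CCC(CC)c1nn(CCCO)c2c1N=C(c1ccccc1)CNC2=O`) keeps the chain of compound 3 and changes one group: phenyl in place of 3,4-dimethoxyphenyl on a carbon with a double bond to nitrogen. Among the compounds with values here, no measured pair isolates this change, so the size of the step in this assay cannot be read directly. The closest guide is compound 1, which also carries phenyl at that place, has a different chain and gives 0.333 h. A modest drop, near the edge of the scatter, is therefore expected. The expected step is a 2.0-fold lower number from compound 3 to compound 4 (0.31 log units; beyond the scatter). For compound 4 the estimated half-life is 0.36 h, with an expected range of 0.17 h to 0.75 h.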

Compound 4, half-life: 0.6 h
Compound 4: the middle estimate sits 1.7-fold (0.22 log units) below what was measured, within the range that was stated.
By their numbers in this assay, from the lowest: compound 2; then compounds 1, 4 and 3 (each within the scatter of the next, the first and the last beyond it).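

In this assay the swap of 3,4-dimethoxyphenyl for phenyl on the carbon with a double bond to nitrogen moves the half-life only within the scatter (a 1.2-fold lower number from compound 3 to compound 4 (0.09 log units; within the scatter)), so the two methoxy groups make no readable difference at this position. Within the data shown here, by contrast, hydrogen in place of 2-methyl-1H-imidazol-1-yl on an aromatic carbon gives a step beyond the scatter (a 6.0-fold higher number from compound 2 to compound 4 (0.78 log units; beyond the scatter)), which makes this the only one of the three changes that clearly separates two compounds. Hydroxymethyl in place of hydroxy on the saturated chain stays within the scatter (a 1.8-fold higher number from compound 1 to compound 4 (0.26 log units; within the scatter)), so the chain change cannot be read as a gain.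

Nothing shown here accounts for the size of any of these steps. From the compounds shown here alone, it remains open how an amine or a carboxylic acid on the phenyl, or a longer chain bearing the hydroxy group, would affect the half-life.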